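Amino for methyl on the thiadiazole of compound 2

The source may hold more compounds than are shown below. What is called first, only, known or untested is meant among the compounds shown, and "the series" means these compounds.

compound 1 `Nc1nnc(SCc2cc(=O)c3ccccc3o2)s1`: > 25000 nM
compound 2 `Cc1ccc2oc(CSc3nnc(C)s3)cc(=O)c2c1`: > 25000 nM

In a functional assay on HeLa cells (Homo sapiens) for cytotoxicity, read by MTT assay, with a stated time of 72 h (a higher number here means a weaker inhibitor, a lower number a stronger inhibitor), compound 2 gives > 25000 nM, a limit of the assay and not a number. Compound 1 also sits at a limit in this assay, > 25000 nM. Both values rest at the limit of > 25000 nM in this assay, at which 2 of the 2 values shown sit. Compound 3 `Cc1ccc2oc(CSc3nnc(N)s3)cc(=O)c2c1` differs from compound 2 by amino in place of methyl on an aromatic carbon. Within the data shown here, no step between measured compounds exists here. Since compound 1 carries the same amino group and sits at > 25000 nM in this assay, the expected step is a step that the limit leaves unreadable from compound 2 to compound 3, none beyond the scatter. Compound 3 is expected at 40000 nM, between 15000 nM and 200000 nM, most likely reported only as a limit.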

Compound 3, half-maximal inhibitory concentration: > 25000 nM
Compound 3: only a limit was reported; the forecaster's own chance of this, stated with the estimate: 90%; the middle value lies beyond the limit too.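

No new step can be read among compound 1, compound 2 and compound 3, because each value is a limit of the assay and not a number: the limit of > 25000 nM in this assay, at which 3 of the 3 values shown sit.

The compounds shown leave open how potent any of the three is, and whether amino in place of methyl changes that potency at all.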